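Cytotoxicity notes on the fluoro-to-chloro swap

The source may hold more compounds than are shown below. What is called first, only, known or untested is meant among the compounds shown, and "the series" means these compounds.

The series shares one core and varies the aryl group on the carbonyl carbon. Compound 1 `COC(=O)c1cc(-c2cccc(NC(=O)c3ccc(/C=C/C(=O)c4ccc(F)cc4)cc3)c2)on1` is the reference here. In an ADME assay on Vero cells (Chlorocebus sabaeus) for cytotoxicity, read by MTT assay, with a stated time of 72 h (a lower number here means that less compound is tolerated, a higher number that more compound is tolerated), compound 1 gives > 20 ug/mL, which is a limit of the assay and not a number. Compound 2 `CCCOc1ccc(C(=O)/C=C/c2ccc(C(=O)Nc3cccc(-c4cc(C(=O)OC)no4)c3)cc2)cc1` carries propoxy in place of fluoro on an aromatic carbon; in this assay compound 2 gives > 40 ug/mL, again a limit. Compound 3 `COC(=O)c1cc(-c2cccc(NC(=O)c3ccc(/C=C/C(=O)c4ccccc4Br)cc3)c2)on1` carries 2-bromophenyl in place of 4-fluorophenyl on the carbonyl carbon; in this assay compound 3 gives > 40 ug/mL, also a limit. The three steps among them read a step that the two limits leave unreadable from compound 1 to compound 2, a step that the two limits leave unreadable from compound 1 to compound 3 and a step that the two limits leave unreadable from compound 2 to compound 3: none yields a size, and the evidence is confined to the limit of > 20 ug/mL in this assay, at which 1 of the 3 values shown sits, and (the limit of > 40 ug/mL in this assay, at which 2 of the 3 values shown sit). Compound 1 thus stands at the lower of the two limits seen, with no number to place it more closely.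

Compound 4 `COC(=O)c1cc(-c2cccc(NC(=O)c3ccc(/C=C/C(=O)c4ccc(Cl)cc4)cc3)c2)on1` differs from compound 1 in one place: chloro in place of fluoro on an aromatic carbon. Among the compounds with values here, no measured step bears on this change with a readable size. Every aryl variant reached a limit, so a step in this assay beyond the scatter is not expected in either direction. Compound 4 is expected to give 40 ug/mL (range 20 ug/mL to 80 ug/mL), most likely again as a limit. That estimate would mean a step that the limit leaves unreadable from compound 1 to compound 4.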

Compound 4, half-maximal cytotoxic concentration: > 50 ug/mL
Compound 4 ended at the assay's limit; the forecaster's own chance of this, stated with the estimate: 85%; middle value at least 1.2-fold (0.09 log units) away from the limit.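

In this assay compound 4 gives > 50 ug/mL, a limit and not a number. Within the data shown here, compound 1, compound 2 and compound 3 also stand at limits, and no step linking any of them to compound 4 can be read. The compounds shown leave open the concentration at which any of the four reaches half-maximal cytotoxicity, and whether the aryl group on the carbonyl carbon changes it.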